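This account rests on a few compounds, and the source may have more. Where it says the series, first, only, none or still open, it means among the compounds named here.

Measured in a functional assay on KB cells (Homo sapiens) for cytotoxicity; a lower number here means that less compound is needed, a higher number that more compound is needed for the effect:
- Compound 1 `Clc1ccc2c(N/N=C/c3cnc[nH]3)ccnc2c1`: 29.1 uM
- Compound 2 `FC(F)(F)c1ccc(-c2n[nH]cc2/C=N/Nc2ccnc3cc(Cl)ccc23)cc1`: 1.2 uM

Compound 1 stands at the higher of the two numbers in this assay, so more of it is needed for the effect, and its gap to compound 2 lies beyond the usual scatter. Compound 3 `Clc1ccc2c(N/N=C/c3ccc[nH]3)ccnc2c1` keeps the core of compound 1 and changes one group: 1H-pyrrol-2-yl in place of 1H-imidazol-5-yl on a carbon with a double bond to nitrogen. Here 1H-pyrrol-2-yl stands in place of 1H-imidazol-5-yl on a carbon with a double bond to nitrogen. For the measured compounds named here, no measured pair shows this change alone, so the data give only weak guidance. Compound 2, at 1.2 uM, shows that a much lower number occurs in this small set, while compound 1 marks its upper end. A modest step to a lower number in this assay is therefore expected, though it may not clear the scatter. The estimated change is a 2.4-fold lower number from compound 1 to compound 3 (0.38 log units; beyond the scatter). For compound 3 the expected value is 12 uM, with an estimated range from 3.5 uM to 40 uM.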

Compound 3, concentration for half-maximal effect: 4.8 uM
Estimate against measurement, compound 3: 2.5-fold (0.40 log units) above; the measured number falls inside the stated range.
By their numbers in this assay, from the lowest: compound 2; then compound 3; then compound 1.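

Within this assay, placing 1H-pyrrol-2-yl in place of 1H-imidazol-5-yl on a carbon with a double bond to nitrogen gives a 6.1-fold lower number from compound 1 to compound 3 (0.78 log units; beyond the scatter), the only step shown in which the core of compound 1 stays unchanged. This shows that the number in this assay responds to the choice of ring at this position, even though the group that leaves and the group that enters are both five-membered aromatic rings with the same number of heavy atoms and the same number of hydrogen-bond donors. They differ in their ring atoms and in the count of hydrogen-bond acceptors, but nothing at hand bears on why the number falls with this change.

For the compounds shown here, the single step does not show whether the shift follows from the ring nitrogen that is lost or is particular to 1H-pyrrol-2-yl, a question that a furan-2-yl or pyridin-2-yl group at the same place could address. From the compounds shown here alone, compound 2 differs from compound 1 in more than one place, so how much of its gap to compound 1 belongs to any single part of its structure also remains open.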